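This account rests on a few compounds, and the source may have more. Where it says the series, first, only, none or still open, it means among the compounds named here.

In an in vitro ADME assay on microsomes from Gut (Homo sapiens) for metabolic stability, in the presence of a further agent that is not named here; a lower number here means slower removal, a higher number faster removal of the compound:
Compound 1 `CC(C)(CO)CNC(=O)c1cc2cc(C#N)ccc2n1Cc1cccc(OC(F)(F)F)c1`: 136 mL.min-1.g-1
Compound 2 `CCCOc1cccc(Cn2c(C(=O)NCC(C)(C)CO)cc3cc(C#N)ccc32)c1`: 45 mL.min-1.g-1
Compound 3 `CC(O)C1(CNC(=O)c2cc3cc(C#N)ccc3n2Cc2cccc(OC(F)(F)F)c2)CCCC1`: not yet measured

Of the two measured compounds, compound 1 stands highest in this assay, at 136 mL.min-1.g-1. The change to compound 3 keeps the core of compound 1 and alters only the amide side: a group of 8 heavy atoms (7 carbon, 1 oxygen; one five-membered non-aromatic ring of carbon only) in place of a group of 5 heavy atoms (4 carbon, 1 oxygen; no ring), on a saturated chain carbon bound to an amide-type nitrogen. Going by the values given here, the one measured step, a 3.0-fold lower number from compound 1 to compound 2 (0.48 log units; beyond the scatter), is modest but beyond the scatter. It concerns the group on the oxygen on the aromatic ring, so it bears only indirectly on this change. Among the compounds with values here, no measured step covers a change on a saturated chain carbon bound to an amide-type nitrogen. A step no larger than that modest one is therefore expected, most likely none beyond the scatter, with no firm direction. The expected step is a 1.0-fold higher number from compound 1 to compound 3 (0.01 log units; within the scatter). Compound 3 is estimated at 140 mL.min-1.g-1, with an expected range of 65 mL.min-1.g-1 to 300 mL.min-1.g-1.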

Compound 3, intrinsic clearance in microsomes: < 6 mL.min-1.g-1
Compound 3: no number, only a limit; the forecaster's own chance of this, stated with the estimate: 2%; middle value at least 23-fold (1.36 log units) from the limit.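

Notes on the amide side: the place on a saturated chain carbon bound to an amide-type nitrogen turns out to have a large effect on this read-out, with an at least 22-fold lower number from compound 1 to compound 3 (1.35 log units; beyond the scatter) in this assay, whereas the earlier change on the oxygen gave a 3.0-fold lower number from compound 1 to compound 2 (0.48 log units; beyond the scatter). This step comes with no change in the counts of hydrogen-bond donors and acceptors and no net charge, so those counts do not separate compound 1 from compound 3, even though the group entering is larger and carries a five-membered carbon ring. Compound 3 has a limit and not a number, so the full size of the step stays unknown: the limit of < 6 mL.min-1.g-1 in this assay, at which 1 of the 3 values shown sits.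

From the compounds shown here alone, it remains open whether the ring itself or the rest of the entering group carries the step, and whether a six-membered carbon ring or an amine at this place would behave alike. Going by these compounds, it is also open whether the step holds with propyl on the oxygen, as in compound 2.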